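This account rests on a few compounds, and the source may have more. Where it says the series, first, only, none or still open, it means among the compounds named here.

Measured so far:
compound 1 `Cc1cc(-c2ccc(O)cc2)c2ncc(CSCCc3ccccc3)n2c1` — 20 ug/mL
compound 2 `COc1cccc(-c2cc(C)c3ncc(CSCCc4ccccc4)n3c2)c1` — 20 ug/mL

Among the compounds with values here, the two measured members share one core and differ only in the aryl group attached to it. In an ADME assay on HEL cells (Homo sapiens) for cytotoxicity, with a stated time of 3 days (a higher number here means that more compound is tolerated, a lower number that less compound is tolerated), compound 1 gives 20 ug/mL. Compound 2, carrying a methoxyphenyl in place of the hydroxyphenyl, gives 20 ug/mL in this assay. Compound 1 therefore stands level with compound 2 at the digits reported; the two values lie within the scatter of the method, and no order between them can be read.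

Compound 3 `Cc1cc(-c2cccs2)c2ncc(CSCCc3ccccc3)n2c1` has not been measured. It departs from compound 1 by one change:

thiophen-2-yl in place of 4-hydroxyphenyl on an aromatic carbon

Within the data shown here, no step between measured compounds bears on this exchange, so the expectation for compound 3 in this assay rests on the observation that the aryl swap from compound 1 to compound 2 left the value unchanged. The change from compound 1 to compound 3 is expected to be no change at the digits printed from compound 1 to compound 3 (within the scatter), that is, no step beyond the scatter. For compound 3 in this assay a value of 20 ug/mL is estimated, within the range 10 ug/mL to 40 ug/mL.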

Compound 3, minimum cytotoxic concentration: 100 ug/mL
Compound 3: middle estimate off by 5.0-fold (0.70 log units), on the low side, outside the stated range (above it).
By their numbers in this assay, from the lowest: compounds 1 and 2 (each within the scatter of the next); then compound 3.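

In this assay, the aryl position on the shared core is not indifferent to the group it carries: thiophen-2-yl in place of 4-hydroxyphenyl gives a 5.0-fold higher number from compound 1 to compound 3 (0.70 log units; beyond the scatter), whereas compound 1 at 20 ug/mL and compound 2 at 20 ug/mL showed no separation. Within the data shown here, this exchange replaces a six-membered aromatic ring of carbon only with a five-membered aromatic ring with 1 hetero atom and also removes the hydrogen-bond donor, so the single step cannot assign the higher number to any one of these differences, although compound 2 also lacks the hydroxyl of compound 1 and stays level with it. Nothing at hand explains the step.

On these data alone, it remains open whether the step belongs to thiophen-2-yl specifically or extends to other five-membered rings, and furan-2-yl, thiophen-3-yl or unsubstituted phenyl at this position would help separate ring size from the sulfur atom. As far as these compounds go, it also remains open whether the same step would appear if the side chain of the shared core were replaced by a shorter chain or one carrying an amine.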